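The source may hold more compounds than are shown below. What is called first, only, known or untested is meant among the compounds shown, and "the series" means these compounds.

The three measured compounds in a functional assay on B16-F10 cells (Mus musculus) for cytotoxicity, read by MTT assay, with a stated time of 48 h; on this read-out lower numbers stand for stronger inhibition and higher numbers for weaker inhibition:

Compound 1 `Cc1ccc2nc(Nc3nc4ccccc4s3)sc2c1` gives > 50000 nM, which is a limit of the assay and not a number.
Compound 2 `Clc1ccc2nc(Nc3nc4ccccc4s3)sc2c1` gives > 50000 nM, likewise a limit.
Compound 3 `Cc1ccc2nc(Nc3nc4ccc(F)cc4s3)sc2c1` gives 29600 nM.

Within the data shown here, compound 3 therefore holds the only number among the three; the other two sit at the limit of > 50000 nM in this assay, at which 2 of the 3 values shown sit. The step that the two limits leave unreadable from compound 1 to compound 2 cannot be read. The step of an at least 1.6-fold lower number from compound 1 to compound 3 (0.22 log units; that floor lies within the scatter) rests on (fluoro in place of hydrogen on an aromatic carbon).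

Compound 4 `Fc1ccc2nc(Nc3nc4ccc(Cl)cc4s3)sc2c1` has not yet been measured. It differs from compound 3 by chloro in place of methyl on an aromatic carbon, the same change as chloro in place of methyl on an aromatic carbon, made twice in all and at the same place; the two cores differ by fluoro in place of hydrogen on an aromatic carbon. The earlier instance, a step that the two limits leave unreadable from compound 1 to compound 2, yields no readable size, so no measured guide to this change exists. Compound 4 is expected to land close to compound 3, an estimated step of a 1.0-fold higher number from compound 3 to compound 4 (0.01 log units; within the scatter), because compound 3 gives 29600 nM and the change is small in what it counts. Compound 4 is estimated at 30000 nM, between 12000 nM and 75000 nM.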

Compound 4, half-maximal inhibitory concentration: 41900 nM
Compound 4: the middle estimate sits 1.4-fold (0.15 log units) below what was measured, within the range that was stated.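

In this assay, chloro in place of methyl gives a 1.4-fold higher number from compound 3 to compound 4 (0.15 log units; within the scatter), and fluoro in place of hydrogen gives an at least 1.1-fold lower number from compound 2 to compound 4 (0.07 log units; that floor lies within the scatter). The fluoro change can be followed on two cores, but only as floors: the same change on two cores in this assay, an at least 1.6-fold lower number (0.22 log units; that floor lies within the scatter) from compound 1 to compound 3 and an at least 1.1-fold lower number (0.07 log units; that floor lies within the scatter) from compound 2 to compound 4; the limit leaves it open whether they differ. These pairs therefore do not show that the fluoro change carries over from one core to another with the same size, only that both floors and the chloro-for-methyl step from compound 3 lie within the scatter; the step from compound 1 to compound 2 cannot be read, so the chloro-for-methyl change has just one measured size in this series.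

The compounds shown leave open how the values would respond to an amine or a carboxylic acid on the shared core, in place of methyl, chloro or fluoro. They also leave open whether a longer chain in place of methyl would give a step beyond the scatter from compound 3.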